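The compounds below may be only part of what the source reports. "The series", "measured", "known", "first", "only" and "open" are said of these compounds alone.

Three compounds share one core and differ only in the ring carried on the chain carbon bound to sulfur. Compound 3 `c1ccc(CSc2nnc(-c3ccncc3)n2-c2ccccc2)cc1` bears a plain phenyl there, and in a functional assay on MCF7 cells (Homo sapiens) for inhibition, read by MTT assay, with a stated time of 48 h (on this read-out higher numbers stand for weaker inhibition and lower numbers for stronger inhibition), compound 3 gives 22400 nM, the highest of the two numbers obtained. Compound 2 `Clc1cccc(CSc2nnc(-c3ccncc3)n2-c2ccccc2)c1` gives 10500 nM in this assay. For compound 1 `Fc1ccccc1CSc1nnc(-c2ccncc2)n1-c1ccccc1` this assay returned only a limit, > 50000 nM. Compound 4 `O=[N+]([O-])c1ccccc1CSc1nnc(-c2ccncc2)n1-c1ccccc1` differs from compound 3 by nitro in place of hydrogen on an aromatic carbon. Within the data shown here, two measured steps bear on this: an at least 2.2-fold lower number from compound 1 to compound 3 (0.34 log units; beyond the scatter), where the 2-fluorophenyl of compound 1 went with the poorer result, and a 2.1-fold higher number from compound 2 to compound 3 (0.33 log units; beyond the scatter). A nitro entering where the fluoro of compound 1 sat is therefore expected to give a similar or higher number, a 1.3-fold higher number from compound 3 to compound 4 (0.13 log units; within the scatter). Compound 4 is estimated at 30000 nM, between 10000 nM and 90000 nM.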

Compound 4, half-maximal inhibitory concentration: > 50000 nM
Compound 4 ended at the assay's limit (the forecaster's own chance of this, stated with the estimate: 30%); at least 1.6-fold (0.22 log units) between middle value and limit.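

In this assay, nitro on the phenyl ring goes with weaker inhibition, an at least 2.2-fold higher number from compound 3 to compound 4 (0.34 log units; beyond the scatter), and the 2-nitrophenyl also falls behind the 3-chlorophenyl, an at least 4.7-fold higher number from compound 2 to compound 4 (0.67 log units; beyond the scatter). The 2-nitrophenyl of compound 4 now joins the 2-fluorophenyl of compound 1 at a limit of the assay rather than at a measured number: the limit of > 50000 nM in this assay, at which 2 of the 4 values shown sit. The step between these two compounds cannot be read.

The compounds shown leave open how an amine or a carboxylic acid on this ring would read. They also leave open how a nitro would read where compound 2 carries its chloro.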